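A benzyl-to-trimethylphenyl swap on a chlorinated pyrimidine core

The compounds below may be only part of what the source reports. "The series", "measured", "known", "first", "only" and "open" are said of these compounds alone.

Among the measured compounds shown here, compound 3 `CN1CCN(c2ccc(Nc3ncc(Cl)c(NCc4ccccc4)n3)nc2)CC1` is the one compound here with a measured number. In a functional assay on MDA-MB-231 cells (Homo sapiens) for inhibition, read by CCK-8 assay, with a stated time of 48 h (on this read-out higher numbers stand for weaker inhibition of growth and lower numbers for stronger inhibition of growth), compound 3 gives 24800 nM. The other two compounds are known only by a limit of the assay (the limit of > 100000 nM in this assay, at which 2 of the 3 values shown sit). Compound 1 `Cc1ccccc1Nc1nc(NCc2ccccc2)ncc1Cl` gives > 100000 nM in this assay, which is a limit and not a number. Compound 2 `Cc1ccccc1Nc1nc(NCc2ccco2)ncc1Cl` gives > 100000 nM in this assay, likewise a limit. The step that the two limits leave unreadable from compound 1 to compound 2 therefore has no readable size.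

Compound 4 `Cc1cc(C)c(Nc2nc(Nc3ccc(N4CCN(C)CC4)cn3)ncc2Cl)c(C)c1` keeps the core of compound 3 and changes one group: 2,4,6-trimethylphenyl in place of benzyl on a nitrogen on an aromatic ring. For the measured compounds named here, no measured step among the three compounds above involves this change, and the only readable step elsewhere is unreadable, so nothing in the data sets a direction or a size for the move from compound 3 to compound 4. The expectation must rest on compound 3 alone, with a wide band around its value of 24800 nM.

Compound 4 is therefore estimated at 12000 nM in this assay, within a range of 1500 nM to 80000 nM, which corresponds to an expected step of a 2.1-fold lower number from compound 3 to compound 4 (0.32 log units; beyond the scatter) that is not claimed to be beyond the scatter.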

Compound 4, concentration for 50% growth inhibition: 21000 nM
The estimate for compound 4 lay 1.8-fold (0.24 log units) below the measured number; the measured number falls inside the stated range.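

Putting 2,4,6-trimethylphenyl in place of benzyl on a nitrogen on an aromatic ring gives a 1.2-fold lower number from compound 3 to compound 4 (0.07 log units; within the scatter) in this assay. This pair therefore shows that the read-out does not separate these two groups at this place, although benzyl has 7 heavy atoms and 2,4,6-trimethylphenyl has 9, and the cut one bond further out reads benzylamino to (2,4,6-trimethylphenyl)amino. It is the only step among the compounds shown that can be read at all, since the step between compound 1 and compound 2 joins two limits of the assay and has no size: the limit of > 100000 nM in this assay, at which 2 of the 4 values shown sit.

The compounds shown leave open whether a different kind of group on this nitrogen, such as a longer chain ending in phenyl or a chain carrying a carboxylic acid, would give a step beyond the scatter. They also leave open whether the same exchange of benzyl for 2,4,6-trimethylphenyl would read the same with another group elsewhere on the shared core.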